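The compounds below may be only part of what the source reports. "The series", "measured", "known", "first", "only" and "open" are said of these compounds alone.

Compound 1 `COc1ccc2sc(NC(=O)c3ccc(C)cc3)nc2c1`: > 10 ug/mL
Compound 2 `COc1ccc(C(=O)Nc2nc3cc(OC)ccc3s2)cc1`: > 10 ug/mL
Compound 3 `Cc1cc(C)c2sc(NC(=O)c3ccc(C(F)(F)F)cc3)nc2c1`: 1.36 ug/mL

Three compounds sharing the same amide linkage have so far been run in a functional assay on SK-HEP1 cells (Homo sapiens) for antiproliferative activity, read by sulforhodamine B assay; on this read-out higher numbers stand for weaker inhibition of growth and lower numbers for stronger inhibition of growth. Compound 1 gives only a limit of the assay, > 10 ug/mL. Compound 2 likewise gives only a limit, > 10 ug/mL, so compound 2 sits at the limit of > 10 ug/mL in this assay, at which 2 of the 3 values shown sit, without a number of its own. The step that the two limits leave unreadable from compound 1 to compound 2 is accordingly unreadable. Compound 3 differs from compound 2 both in its core and in the substituent on the amide ring. In this assay compound 3 gives an actual number, 1.36 ug/mL. Within the data shown here, no single-point step connects compound 3 to compound 2, so what compound 3 shows can only be set beside what compound 1 and compound 2 show.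

Compound 4 `COc1ccc2sc(NC(=O)c3ccc([N+](=O)[O-])cc3)nc2c1` is the next compound: nitro in place of methoxy on an aromatic carbon. Among the measured compounds shown here, no measured step bears on this exchange; the one measured step, a step that the two limits leave unreadable from compound 1 to compound 2, concerns a different position and has no readable size. The expectation for compound 4 rests only on the spread of the three values shown, two at the limit and one at a number. Compound 4 is expected to give 7 ug/mL in this assay, within a range from 2.5 ug/mL to 15 ug/mL. This corresponds to an expected step of an at least 1.4-fold lower number from compound 2 to compound 4 (0.15 log units; that floor lies within the scatter), to be judged only once compound 4 has been measured.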

Compound 4, concentration for 50% growth inhibition: > 10 ug/mL
Compound 4: only a limit was reported (the forecaster's own chance of this, stated with the estimate: 45%); at least 1.4-fold (0.15 log units) between middle value and limit.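

In this assay compound 4 gives only a limit, > 10 ug/mL. The steps to compound 4 from compound 1 and from compound 2 therefore cannot be read, and compound 4 joins the others at that limit: the limit of > 10 ug/mL in this assay, at which 3 of the 4 values shown sit.

The compounds shown leave open whether methyl, methoxy or nitro on the amide ring differ at all in this read-out.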